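The source may hold more compounds than are shown below. What is called first, only, known or untested is meant among the compounds shown, and "the series" means these compounds.

Of the compounds shown here, three that share the same core have been tested in a functional assay on MCF7 cells (Homo sapiens) for inhibition; on this read-out higher numbers stand for weaker inhibition and lower numbers for stronger inhibition. Compound 1 `COc1ccccc1-c1nc2cc(F)ccc2o1` gives 360 nM. Compound 2 `COc1cccc(-c2nc3cc(F)ccc3o2)c1` holds the same atoms joined differently; how the two cores differ is not broken down here. In this assay compound 2 gives 39500 nM, and compound 3 `COc1cc(OC)cc(-c2nc3cc(F)ccc3o2)c1` gives 45400 nM. The change between these two is methoxy in place of hydrogen on an aromatic carbon, and it produced a 1.1-fold higher number from compound 2 to compound 3 (0.06 log units; within the scatter). Among the three, compound 1 holds the lowest number, and its gaps to compound 2 and to compound 3 lie beyond the scatter.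

Compound 4 `COc1cccc(OC)c1-c1nc2cc(F)ccc2o1` is not yet measured. It differs from compound 1 by methoxy in place of hydrogen on an aromatic carbon. Within the data shown here, this is the same kind of change as the one from compound 2 to compound 3, but the place is not the same: in compound 4 the entering methoxy sits ortho to a large group, whereas in compound 3 it sits meta to a large group; in both it is meta to a methoxy group. Among the measured compounds shown here, because the step of a 1.1-fold higher number from compound 2 to compound 3 (0.06 log units; within the scatter) was small, a small step might be expected here as well, yet that step was made at a different place on the ring, and none of the measured compounds shows what a second group ortho to the large group does. For compound 4 a step of a 3.3-fold higher number from compound 1 to compound 4 (0.52 log units; beyond the scatter) is therefore expected, to allow for the change of place. In this assay compound 4 is estimated to give about 1200 nM, most likely between 250 nM and 8000 nM.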

Compound 4, half-maximal inhibitory concentration: 58100 nM
Beside the measured number, compound 4's estimate is 48-fold (1.68 log units) below it; the measured number lies above the stated range.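

In this assay, among these compounds, putting a methoxy in place of a hydrogen on an aromatic carbon of compound 1 gave a 160-fold higher number from compound 1 to compound 4 (2.21 log units; beyond the scatter), a large loss of inhibition from a change of only one small group. This change therefore cannot simply be carried from one core to the other in this series, since the size of the step measured on one core did not predict the size of the step on the other: the same change on two cores in this assay, a 1.1-fold higher number (0.06 log units; within the scatter) from compound 2 to compound 3 and a 160-fold higher number (2.21 log units; beyond the scatter) from compound 1 to compound 4, 140-fold (2.15 log units) apart, beyond the scatter of two such steps. What this does not show is why the two steps differ, since each core offers just one example, and the entering methoxy also sits in a different place on each: in compound 4 it is ortho to a large group, so the core and the place cannot be told apart.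

Going by these compounds, it remains open whether a methoxy added to the core of compound 1 at the place used in compound 3 would give a small step or a large one, which would help to separate the effect of the core from that of the place. On these data alone, it is also open whether a methyl, a chlorine or a hydroxyl entering at the place filled in compound 4 would give a step as large as the one seen with methoxy.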